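This account rests on a few compounds, and the source may have more. Where it says the series, first, only, none or still open, it means among the compounds named here.

Measured so far in an ADME assay on Raji cells (Homo sapiens) for cytotoxicity, read by CellTiter-Glo and resazurin assay, with a stated time of 72 h; on this read-out higher numbers stand for an effect only at larger amounts of compound and lower numbers for an effect already at smaller amounts: compound 1 `CC(C)N(Cc1cccc(OCCCCCC(=O)O)c1)C(=O)c1ccc(-c2ccncc2)cc1`, > 26000 nM; compound 2 `CC(C)N(Cc1cccc(OCCCCCC(=O)O)c1)C(=O)c1ccc(-c2cccc(-c3ccccc3)c2)cc1`, > 26000 nM; compound 3 `CCOC(=O)CCCCCOc1cccc(CN(C(=O)c2ccc(-c3ccncc3)cc2)C(C)C)c1`, > 26000 nM.

In this assay compound 1 gives no number but only a limit of the assay, > 26000 nM. Compound 2 is likewise reported only as a limit, > 26000 nM. Compound 3 also stands at a limit, > 26000 nM. The two steps between them stay unreadable because the limit of > 26000 nM in this assay, at which 3 of the 3 values shown sit, holds every value: a step that the two limits leave unreadable from compound 1 to compound 2 and a step that the two limits leave unreadable from compound 1 to compound 3.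

The change from compound 1 to compound 2 is 3-phenylphenyl in place of pyridin-4-yl on an aromatic carbon. The two cores differ by ethyl in place of hydrogen on an oxygen next to a carbonyl group. Compound 4 `CCOC(=O)CCCCCOc1cccc(CN(C(=O)c2ccc(-c3cccc(-c4ccccc4)c3)cc2)C(C)C)c1` carries the same change on the core of compound 3: 3-phenylphenyl in place of pyridin-4-yl on an aromatic carbon. Since both parents of this change rest at the same limit, its size is not known, and compound 4 is expected to behave as compound 2 did, with an estimated step that the limit leaves unreadable from compound 3 to compound 4 in this assay. Compound 4 is therefore estimated at 35000 nM, expected to lie between 15000 nM and 100000 nM, most likely again reported only as a limit.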

Compound 4, half-maximal effective concentration: > 26000 nM
Compound 4: no number, only a limit; the forecaster's own chance of this, stated with the estimate: 85%; the middle value does not contradict the limit.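

In this assay compound 4 is reported only as a limit, > 26000 nM. Its steps from compound 3 and from compound 2 cannot be read, because all the compounds shown rest at the same limit: the limit of > 26000 nM in this assay, at which 4 of the 4 values shown sit.

The compounds shown leave open how large either change is and at what concentration any of them would show cytotoxicity.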